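Moving the chlorine on the benzylthio arm of compound 2

A few compounds are considered here, and "the series" means these few. Any claim that something is new, unique, unknown or untested is made for them only; others in the source may bear on it.

Compound 2 `Cc1c(O)nc(SCc2ccc(Cl)cc2)nc1Cc1c(Cl)cccc1Cl` sits in a functional assay on MT4 cells (Homo sapiens) for cytotoxicity, read by MTT assay (a lower number here means that less compound is tolerated, a higher number that more compound is tolerated), at a limit of the assay rather than at a number, > 59000 nM. That is the limit (the limit of > 59000 nM in this assay, at which 1 of the 3 values shown sits). Compound 1 `Cc1c(Cc2c(F)cccc2F)nc(SCc2ccc([N+](=O)[O-])cc2)[nH]c1=O` also stops at a limit in this assay, > 62000 nM. That is the limit (the limit of > 62000 nM in this assay, at which 1 of the 3 values shown sits). Among the measured compounds shown here, compound 3 `CCCCOc1ccc(CSc2nc(O)c(C)c(Cc3c(Cl)cccc3Cl)n2)cc1` is the one member with a measured number; in this assay compound 3 gives 3100 nM.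

For the measured compounds named here, the single measured step, an at least 19-fold lower number from compound 2 to compound 3 (1.27 log units; beyond the scatter), puts butoxy in place of chloro, a change of another kind than the one considered here. Compound 4 `Cc1c(O)nc(SCc2cccc(Cl)c2)nc1Cc1c(Cl)cccc1Cl` differs from compound 2 by 3-chlorophenyl in place of 4-chlorophenyl on a saturated chain carbon bound to a sulfur. Going by the values given here, no measured step moves a chloro within the ring, so none of the measured steps bears on this change, and the expectation is no step beyond the scatter in this assay. Compound 4 is therefore estimated to stay near the limit of compound 2, with the step expected to be a step that the limit leaves unreadable from compound 2 to compound 4. For compound 4 the estimated value in this assay is 60000 nM, within 20000 nM to 130000 nM.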

Compound 4, half-maximal cytotoxic concentration: > 59000 nM
Compound 4: only a limit was reported; the forecaster's own chance of this, stated with the estimate: 70%; the middle value lies beyond the limit too.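

Among the compounds shown here, compound 2 and compound 4 both stop at the same limit, so no step between them can be read: the limit of > 59000 nM in this assay, at which 2 of the 4 values shown sit. The compounds shown leave open whether 3-chlorophenyl and 4-chlorophenyl differ at all in cytotoxicity, as neither compound reaches a measured number.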